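Toward a cytotoxicity estimate for compound 4

A few compounds are considered here, and "the series" means these few. Any claim that something is new, unique, unknown or untested is made for them only; others in the source may bear on it.

Measured in an ADME assay on MT4 cells (Homo sapiens) for cytotoxicity, read by MTT assay; on this read-out lower numbers stand for higher toxicity in this test and higher numbers for lower toxicity in this test:
Compound 1 `Cc1cc(C)cc(S(=O)(=O)c2c(C(=O)NCC(=O)NC(C)c3ccccc3)[nH]c3ccc(Cl)cc23)c1`: 29400 nM
Compound 2 `Cc1cc(C)cc(S(=O)(=O)c2c(C(=O)NCC(=O)NCc3ccco3)[nH]c3ccc(Cl)cc23)c1`: > 50000 nM, which is a limit of the assay
Compound 3 `Cc1cc(C)cc(S(=O)(=O)c2c(C(=O)NCC(=O)NC(C)c3ccccc3F)[nH]c3ccc(Cl)cc23)c1`: 23000 nM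

Going by the values given here, compound 3 stands level with the only other exact number, the step being a 1.3-fold lower number from compound 1 to compound 3 (0.11 log units; within the scatter). Its gap to the limit is larger: an at least 2.1-fold lower number from compound 2 to compound 3 (0.33 log units; beyond the scatter). Compound 4 `Cc1cc(C)cc(S(=O)(=O)c2c(C(=O)NCC(=O)NCCn3c(C)cnc3[N+](=O)[O-])[nH]c3ccc(Cl)cc23)c1` carries a new group on the amide-type nitrogen: a group of 11 heavy atoms (6 carbon, 3 nitrogen, 2 oxygen; one five-membered aromatic ring with 2 hetero atoms) in place of a group of 9 heavy atoms (8 carbon, 1 fluorine; one six-membered aromatic ring of carbon only), on an amide-type nitrogen. Among the compounds with values here, the nearest precedent for a five-membered aromatic ring on that nitrogen is an at least 1.7-fold higher number from compound 1 to compound 2 (0.23 log units; that floor lies within the scatter), which points upward but stays within the scatter. A small rise, with no step beyond the scatter, is therefore expected in this assay. The expected change is a 1.5-fold higher number from compound 3 to compound 4 (0.18 log units; within the scatter). Compound 4 is estimated at 35000 nM, with an expected range of 14000 nM to 70000 nM.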

Compound 4, half-maximal cytotoxic concentration: 24500 nM
Estimate against measurement, compound 4: 1.4-fold (0.15 log units) above; the measured number falls inside the stated range.
By their numbers in this assay, from the lowest: compounds 3, 4 and 1 (each within the scatter of the next). At a limit, above all of these: compound 2.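

In this assay, a group with a five-membered aromatic ring with 2 hetero atoms on the amide-type nitrogen, in place of 1-(2-fluorophenyl)ethyl or 1-phenylethyl, gives no readable shift: a 1.1-fold higher number from compound 3 to compound 4 (0.03 log units; within the scatter) and a 1.2-fold lower number from compound 1 to compound 4 (0.08 log units; within the scatter). The step involving the (furan-2-yl)methyl compound can be read only as a floor, an at least 2.0-fold lower number from compound 2 to compound 4 (0.30 log units; that floor lies within the scatter), so a five-membered aromatic ring alone does not place a compound at the limit. That floor rests on a limit, not a number: the limit of > 50000 nM in this assay, at which 1 of the 4 values shown sits.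

The compounds shown leave open whether the nitro group on the new ring matters in this read-out. They also leave open whether an amine or a carboxylic acid on that nitrogen's chain would give a step beyond the scatter.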